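The source may report more compounds than this note shows. Statements on the series, on what has been measured and on what is new or still open speak of the compounds shown alone.

Working notes on the series.

Compound 1 `O=C1/C(=C2/C(=O)N([C@@H]3O[C@H](CO)[C@@H](O)[C@H](O)[C@H]3O)c3ccccc32)Nc2ccccc21` is the one compound with a number: in a functional assay on A-427 cells (Homo sapiens) for antiproliferative activity, read by crystal violet staining, with a stated time of 96 h (on this read-out higher numbers stand for weaker inhibition and lower numbers for stronger inhibition), compound 1 gives 11800 nM, and among the entries shown it is the only number, so no ranking against another compound is possible. Compound 2 `C[C@@H]1O[C@H](N2C(=O)/C(=C3\Nc4ccc(Cl)cc4C3=O)c3ccccc32)[C@H](O)[C@H](O)[C@H]1O` carries no result in this assay; in this assay compound 2 is recorded as "not determined" (no result reported).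

Compound 3 `O=C1/C(=C2/C(=O)N([C@@H]3O[C@H](CO)[C@H](O)[C@H](O)[C@H]3O)c3ccccc32)Nc2ccccc21` is the next entry. Against compound 1 the change is the two compounds have the same atoms and bonds and differ only in configuration as drawn: 1 of 6 stereo elements differ; a stereocentre at a saturated ring carbon is drawn S in compound 1 and R in compound 3. Among the compounds with values here, no step between two measured compounds is available to calibrate what such a change in configuration at a saturated ring carbon does in this assay. With nothing to suggest a direction, the expected step from compound 1 to compound 3 is set at a 1.0-fold higher number from compound 1 to compound 3 (0.01 log units; within the scatter), within the usual scatter. Compound 3 is therefore estimated at 12000 nM in this assay, with a range from 4000 nM to 40000 nM to allow for the unknown effect of the altered stereocentre.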

Compound 3, half-maximal inhibitory concentration: 13200 nM
The estimate for compound 3 lay 1.1-fold (0.04 log units) below the measured number, within the range that was stated.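

In this assay, the series now has its first calibrated step for a change of configuration at a saturated ring carbon: a 1.1-fold higher number from compound 1 to compound 3 (0.05 log units; within the scatter). Drawing this stereocentre S or R therefore gives no difference that this read-out can separate, at least on the core of compound 1. The comparison is a clean one, with a single variable: the fact that compounds 1 and 3 differ only in the configuration as drawn.

Going by these compounds, this pair speaks for one stereocentre only, so the other five stereo elements remain untested, and compound 2 still has no number against which to read its different substitution. The compounds shown also leave open what an amine or a carboxylic acid would do in place of the hydroxyl group on this saturated ring carbon, where only the configuration has been varied so far.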